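The source may report more compounds than this note shows. Statements on the series, on what has been measured and on what is new or still open speak of the compounds shown alone.

Compound 1, `CCCCNC(=O)N1CC1C#N`: 18000 nM
Compound 2, `CCNC(=O)N1CC1C#N`: 7000 nM

Among the measured compounds shown here, in a functional assay on WiDr cells (Homo sapiens) for inhibition (a lower number here means a stronger inhibitor, a higher number a weaker inhibitor), compound 2 holds the lower of the two numbers so far; compound 1 stands nearest, and the only measured step, a 2.6-fold lower number from compound 1 to compound 2 (0.41 log units; beyond the scatter), separates them, a change in which butyl on the urea nitrogen was replaced by ethyl. Compound 3, `CNC(=O)N1CC1C#N`, continues along the same chain: hydrogen in place of methyl on a saturated chain carbon bound to an amide-type nitrogen. For the measured compounds named here, the one measured step that bears on this, a 2.6-fold lower number from compound 1 to compound 2 (0.41 log units; beyond the scatter), was modest but beyond the scatter and pointed toward stronger inhibition as the chain was shortened. Compound 3 shortens it once more, though by less than before, so a step of similar or smaller size in the same direction is the reasonable expectation in this assay, with a flat result within the scatter also possible. For compound 3 the expected step is a 1.8-fold lower number from compound 2 to compound 3 (0.24 log units; within the scatter). The estimate for compound 3 is therefore 4000 nM, ranging from 1500 nM to 12000 nM.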

Compound 3, half-maximal inhibitory concentration: 23000 nM
Beside the measured number, compound 3's estimate is 5.8-fold (0.76 log units) below it, outside the stated range (above it).
By their numbers in this assay, from the lowest: compound 2; then compounds 1 and 3 (each within the scatter of the next).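

Shortening the chain once more does not continue the earlier gain: in this assay, going from ethyl to methyl on the urea nitrogen gives a 3.3-fold higher number from compound 2 to compound 3 (0.52 log units; beyond the scatter). The two ends of the series also cannot be told apart, with a 1.3-fold higher number from compound 1 to compound 3 (0.11 log units; within the scatter), so butyl and methyl give the same result within the usual variation between repeat measurements. Among these three compounds, the effect of chain length is therefore a turn rather than a steady trend, with compound 2, the ethyl compound, as the strongest inhibitor and its steps to both others beyond the scatter.

Where the best length lies remains open, since a propyl chain would fall in the gap between ethyl and butyl, and a branched isopropyl group would test chain shape. The data shown offer no evidence on why the numbers turn at this position.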